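This account rests on a few compounds, and the source may have more. Where it says the series, first, only, none or still open, it means among the compounds named here.

The study concerns a small set of compounds built on a shared core and tested in a functional assay on MGC-803 cells (Homo sapiens) for antiproliferative activity, read by MTT assay, with a stated time of 72 h; a lower number here means a stronger inhibitor, a higher number a weaker inhibitor. Compound 1 `COc1ccccc1/C=C/C(=O)c1ccc(OCC(=O)N[C@H]2CCOC2=O)cc1` gives 39400 nM in this assay, the only numerical result among the three measured compounds. Compound 2 `O=C(CNc1ccc(Cl)cc1Cl)N[C@H]1CCOC1=O` gives > 64000 nM in this assay, which is a limit of the assay and not a number. Compound 3 `O=C(CNc1ccc(Br)cc1)N[C@H]1CCOC1=O` likewise gives > 64000 nM in this assay, again a limit. Going by the values given here, compound 1 therefore stands alone as the one measured number, set against (the limit of > 64000 nM in this assay, at which 2 of the 3 values shown sit). Among the compounds with values here, no pair of measured compounds differing in a single place exists here, so no measured step can be drawn on.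

Compound 4 `O=C(COc1ccc(C(=O)/C=C/c2cccc([N+](=O)[O-])c2)cc1)N[C@H]1CCOC1=O`, not yet measured, differs from compound 1 by 3-nitrophenyl in place of 2-methoxyphenyl on a double-bonded chain carbon bound to a double-bonded chain carbon. Without a measured step to guide it, the change is expected to fall within the scatter of this assay, leaning if anything toward a slightly stronger inhibitor. Compound 4 is estimated at 22000 nM, with a range from 7000 nM to 64000 nM. The expected step from compound 1 to compound 4 is a 1.8-fold lower number from compound 1 to compound 4 (0.25 log units; within the scatter).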

Compound 4, half-maximal inhibitory concentration: > 64000 nM
Compound 4: a limit, no number (the forecaster's own chance of this, stated with the estimate: 15%); middle value at least 2.9-fold (0.46 log units) from the limit.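

In this assay, the change to 3-nitrophenyl in place of 2-methoxyphenyl on a double-bonded chain carbon bound to a double-bonded chain carbon gives an at least 1.6-fold higher number from compound 1 to compound 4 (0.21 log units; that floor lies within the scatter). Compound 4 gives > 64000 nM, which is a limit of the assay and not a number. This first step at this position therefore shows no gain from the 3-nitrophenyl group, and compound 1 remains the only compound with a measured number: the limit of > 64000 nM in this assay, at which 3 of the 4 values shown sit.

Going by these compounds, how far compound 4 lies past its limit cannot be read, so the true size of the step remains unknown. On these data alone, it also remains open whether a plain phenyl group or an aminophenyl group at this place would give a lower number than compound 1 in this assay.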